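Carboxy for hydroxymethyl in a cytotoxic series

This account rests on a few compounds, and the source may have more. Where it says the series, first, only, none or still open, it means among the compounds named here.

Measured in a functional assay on MCF7 cells (Homo sapiens) for cytotoxicity, read by MTT assay; on this read-out lower numbers stand for stronger inhibition and higher numbers for weaker inhibition
compound 1 `COC(=O)C[C@H]1C[C@H](O)[C@@H](C)[C@@H](c2ccc(OC)cc2)N1` 5100 nM
compound 2 `C[C@H]1[C@H](O)C[C@@H](CC(=O)O)N[C@H]1c1ccccc1` 23100 nM
compound 3 `COc1ccc([C@H]2N[C@@H](CCO)C[C@H](O)[C@H]2C)cc1` 13700 nM

Compound 3 stands within the scatter of compound 2 and clearly apart from compound 1. Compound 4 `COc1ccc([C@H]2N[C@@H](CC(=O)O)C[C@H](O)[C@H]2C)cc1` differs from it by carboxy in place of hydroxymethyl on a saturated chain carbon bound to a saturated ring carbon. Among the measured compounds shown here, the one measured step at this place is modest: a 2.7-fold higher number from compound 1 to compound 3 (0.43 log units; beyond the scatter). It does not involve carboxy. Compound 2 does carry carboxy there, with 23100 nM, but differs elsewhere as well. In this assay little change is therefore expected, at most a slight rise. The expected step is a 1.3-fold higher number from compound 3 to compound 4 (0.12 log units; within the scatter), probably within the scatter. Compound 4 is estimated at 18000 nM, with an expected range from 8000 nM to 40000 nM.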

Compound 4, half-maximal inhibitory concentration: 12500 nM
Compound 4: middle estimate off by 1.4-fold (0.16 log units), on the high side, and the stated range covers the measured number.
By their numbers in this assay, from the lowest: compound 1; then compounds 4, 3 and 2 (each within the scatter of the next).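

In this assay, carboxy in place of hydroxymethyl on a saturated chain carbon bound to a saturated ring carbon gives a 1.1-fold lower number from compound 3 to compound 4 (0.04 log units; within the scatter), so here the two groups cannot be told apart. Methoxycarbonyl alone stands apart among these three: hydrogen in place of methyl on an oxygen next to a carbonyl group gives a 2.5-fold higher number from compound 1 to compound 4 (0.39 log units; beyond the scatter), beyond the scatter, and a 2.7-fold higher number from compound 1 to compound 3 (0.43 log units; beyond the scatter) stands beyond it too. No evidence at hand accounts for these numbers. On these data alone, whether an amide would stay with compound 1 remains open, as does where an amine or a longer chain at this place would fall.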